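A few compounds are considered here, and "the series" means these few. Any claim that something is new, unique, unknown or untested is made for them only; others in the source may bear on it.

Values in the series, all from a functional assay, read by spectrophotometry, with a stated time of 30 min (on this read-out lower numbers stand for stronger inhibition and higher numbers for weaker inhibition), as read-out
compound 1 `CC(C)(C)c1cc(CCC(=O)NCC2CCN(Cc3ccccc3)CC2)cc(C(C)(C)C)c1O` at 63400 nM
compound 2 `CC(C)(C)c1cc(/C=C/C(=O)NCCC2CCN(Cc3ccccc3F)CC2)cc(C(C)(C)C)c1O` at 55900 nM

Compound 2 stands within the scatter of compound 1, so these two values set no order between them. The two compounds differ in more than one place, and the data hold no measured size for any single change. Compound 3 `CC(C)(C)c1cc(/C=C/C(=O)NCCC2CCN(Cc3ccc(F)c(F)c3)CC2)cc(C(C)(C)C)c1O` carries 3,4-difluorophenyl in place of 2-fluorophenyl on a saturated chain carbon bound to an amine nitrogen in a ring and has yet to be measured. The expected change is a 1.2-fold lower number from compound 2 to compound 3 (0.09 log units; within the scatter) and amounts to nothing beyond the scatter in this assay for this pair. Compound 3 is estimated at 45000 nM with an expected range of 15000 nM to 100000 nM on this read-out.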

Compound 3, half-maximal inhibitory concentration: 65700 nM
The estimate for compound 3 lay 1.5-fold (0.16 log units) below the measured number, and the stated range covers the measured number.
By their numbers in this assay, from the lowest: compounds 2, 1 and 3 (each within the scatter of the next).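

In this assay, among the compounds shown here, the change from 2-fluorobenzyl to 3,4-difluorobenzyl gives a 1.2-fold higher number from compound 2 to compound 3 (0.07 log units; within the scatter) and is the first single-place step. At this place, on a saturated chain carbon bound to an amine nitrogen in a ring, these two fluorine patterns therefore set no order on the read-out. No measurement shown here offers a reason for this result.

Still open, going by these compounds, is whether a benzyl group carrying a methoxy group or a nitrile, or a pyridylmethyl group in its place, would move the number beyond the scatter. The chain linking the amide to the ring and the saturated or unsaturated link also remain unresolved, since compound 1 differs from compound 2 in more than one place and no single step can be read for either.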